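Tolerated Concentrations Across Three Amide Variants

This account rests on a few compounds, and the source may have more. Where it says the series, first, only, none or still open, it means among the compounds named here.

Compound 1, `C[C@H](NC(=O)[C@]1(Cc2ccccc2)CCN1C(=O)OCc1ccc([N+](=O)[O-])cc1)C(N)=O`: 100000 nM in an ADME assay on HELF cells (Homo sapiens) for cytotoxicity, with a stated time of 3 days; a higher number here means that more compound is tolerated, a lower number that less compound is tolerated
Compound 2, `C[C@H](NC(=O)[C@@]1(Cc2ccccc2)CCN1C(=O)OCc1ccccc1)C(=O)NCc1ccccc1`: >= 20000 nM in this assay
Compound 3, `C[C@H](NC(=O)[C@]1(Cc2ccccc2)CCN1C(=O)OCc1ccccc1)C(=O)N(C)C`: > 100000 nM in this assay

The three measured compounds share one core and differ only in the amide end. Compound 1 gives a plain number in this assay. The value of compound 2 is not a number but a limit of the assay, (the limit of >= 20000 nM in this assay, at which 1 of the 3 values shown sits). The value of compound 3 is also a limit, (the limit of > 100000 nM in this assay, at which 1 of the 3 values shown sits). Compound 2 therefore cannot be placed in order against compound 1 or compound 3; all that is known is that it is tolerated up to the limit recorded for it.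

Compound 4, `CC(C)C[C@H](NC(=O)[C@@]1(Cc2ccccc2)CCN1C(=O)OCc1ccccc1)C(N)=O`, differs from compound 2 in one place: 1-carbamoyl-3-methylbutyl in place of 1-(benzylcarbamoyl)ethyl on an amide-type nitrogen. The amide nitrogen carrying the change keeps a carbonyl carbon as its other neighbour.

Since none of the three measured values lies far from the others and two of them are limits, the account expects no step beyond the scatter from compound 2 to compound 4, a step that the limit leaves unreadable from compound 2 to compound 4. Compound 4 is estimated at 100000 nM, with a range from 20000 nM to 200000 nM, and it is likely that this assay again reports only a limit for compound 4.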

Compound 4, minimum cytotoxic concentration: > 100000 nM
Compound 4: no number, only a limit (the forecaster's own chance of this, stated with the estimate: 70%); the middle value lies on the limit itself.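

In this assay compound 2 and compound 4 both carry only limits of the assay and no number, so the step between them cannot be read. The compounds shown leave open whether 1-carbamoyl-3-methylbutyl in place of 1-(benzylcarbamoyl)ethyl on an amide-type nitrogen changes the tolerated concentration at all, and by how much.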